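The source may report more compounds than this note shows. Statements on the series, on what has been measured and on what is new or still open speak of the compounds shown alone.

Of the compounds shown here, three have been measured in an assay on Sf9 cells for inhibition of serine/threonine-protein kinase 4 (Homo sapiens), read by luminescence and ADP-Glo, with a stated time of 1 h, in the presence of a further agent that is not named here; a higher number here means a weaker inhibitor, a lower number a stronger inhibitor. Compound 1 `CN1CC(=O)N(C)c2cnc(Nc3ccc(S(N)(=O)=O)cc3)nc21` gives 495 nM. Compound 2 `CCC1C(=O)N(C)c2cnc(Nc3ccc(S(N)(=O)=O)cc3)nc2N1C` gives 479 nM. Compound 3 `CN1C(=O)C(c2ccc(F)cc2)N(C)c2nc(Nc3ccc(S(N)(=O)=O)cc3)ncc21` gives 1770 nM, the highest number of the three. The step of a 3.6-fold higher number from compound 1 to compound 3 (0.55 log units; beyond the scatter) and the step of a 3.7-fold higher number from compound 2 to compound 3 (0.57 log units; beyond the scatter) both lie beyond the scatter, whereas the step of a 1.0-fold lower number from compound 1 to compound 2 (0.01 log units; within the scatter) does not. Compound 4 `CN1C(=O)C(c2cccc(C(F)(F)F)c2)N(C)c2nc(Nc3ccc(S(N)(=O)=O)cc3)ncc21` differs from compound 3 in one place: 3-(trifluoromethyl)phenyl in place of 4-fluorophenyl on a saturated ring carbon. Among the compounds with values here, no measured pair exchanges one aryl group for another at this position; the only steps that bear on it are the two that bring in the 4-fluorophenyl group, and both show a modest loss when an aryl group sits on that saturated ring carbon. Since an aryl group is present in compound 3 and in compound 4 alike, the expected step of a 1.1-fold higher number from compound 3 to compound 4 (0.05 log units; within the scatter) in this assay is small and without a clear direction. Compound 4 is estimated in this assay at 2000 nM, with a range from 800 nM to 5000 nM.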

Compound 4, half-maximal inhibitory concentration: 2710 nM
For compound 4 the middle estimate is 1.4-fold (0.13 log units) below the measured one; low and high end bracket the measured number.
By their numbers in this assay, from the lowest: compounds 2 and 1 (each within the scatter of the next); then compounds 3 and 4 (each within the scatter of the next).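

In this assay, the exchange of one aryl group for another on this saturated ring carbon gives a 1.5-fold higher number from compound 3 to compound 4 (0.18 log units; within the scatter), so 3-(trifluoromethyl)phenyl and 4-fluorophenyl are not separated here. The modest loss first seen with 4-fluorophenyl also appears with a second aryl group, as a 5.7-fold higher number from compound 2 to compound 4 (0.75 log units; beyond the scatter) and a 5.5-fold higher number from compound 1 to compound 4 (0.74 log units; beyond the scatter) show for ethyl and hydrogen at the same carbon. No measurement available here offers an explanation for these steps.

Within the data shown here, only two substituted phenyl groups have been compared at this carbon, so it remains open whether the loss extends to an unsubstituted phenyl or a pyridyl ring. As far as these compounds go, the effect of a longer alkyl chain such as butyl, or of an amine or carboxylic acid on the aryl ring, also remains open.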